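The source may hold more compounds than are shown below. What is called first, only, known or untested is meant among the compounds shown, and "the series" means these compounds.

In an ADME assay on microsomes from liver (Homo sapiens) for metabolic stability, read by HPLC, using NADPH, with stated times of 5 min and 60 min, tested at 10 uM (a higher number here means faster removal of the compound, a lower number slower removal), compound 1, with the structure `CCS(=O)(=O)Nc1ccc(Oc2ccccc2)c(-c2cn(C)c(=O)c3[nH]ccc23)c1`, gives only a limit of the assay, < 45 mL/min/kg. Compound 2, with the structure `CCS(=O)(=O)Nc1ccc(Oc2ccc(C(F)(F)F)cc2)c(-c2cn(C)c(=O)c3[nH]ccc23)c1`, gives 128 mL/min/kg in this assay, and compound 3, with the structure `CCS(=O)(=O)Nc1ccc(OCC(C)(C)C)c(-c2cn(C)c(=O)c3[nH]ccc23)c1`, gives 283 mL/min/kg. The measured steps are an at least 2.8-fold higher number from compound 1 to compound 2 (0.45 log units; beyond the scatter), an at least 6.2-fold higher number from compound 1 to compound 3 (0.79 log units; beyond the scatter) and a 2.2-fold higher number from compound 2 to compound 3 (0.34 log units; beyond the scatter), so compound 3 stands highest of the two numbers shown, with compound 2 the nearest. Compound 4, with the structure `CCS(=O)(=O)Nc1ccc(OC2CCC(N(C)C)CC2)c(-c2cn(C)c(=O)c3[nH]ccc23)c1`, is not yet measured in this assay; it differs from compound 3 by 4-(dimethylamino)cyclohexyl in place of neopentyl on an oxygen on an aromatic ring. For the measured compounds named here, the steps from compound 1 to compound 3 and from compound 2 to compound 3 show that exchanging the group on this oxygen moves the clearance by a modest amount, but none of them involves 4-(dimethylamino)cyclohexyl, so no measured step points in a direction here. The change from compound 3 to compound 4 is therefore expected to be a 1.9-fold lower number from compound 3 to compound 4 (0.28 log units; within the scatter), with wide uncertainty. Compound 4 is estimated to give 150 mL/min/kg in this assay, within a range from 50 mL/min/kg to 400 mL/min/kg.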

Compound 4, clearance: < 26.7 mL/min/kg
Compound 4 gave a limit, no number; the forecaster's own chance of this, stated with the estimate: 15%; at least 5.6-fold (0.74 log units) between middle value and limit.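

In this assay, the group on this oxygen can bring the number down sharply: 4-(dimethylamino)cyclohexyl in place of neopentyl gives an at least 10-fold lower number from compound 3 to compound 4 (1.02 log units; beyond the scatter), and in place of 4-(trifluoromethyl)phenyl it gives an at least 4.7-fold lower number from compound 2 to compound 4 (0.68 log units; beyond the scatter). For the compounds shown here, until now, the only group without an aromatic ring on this oxygen was neopentyl, in compound 3, which had the highest number, so compound 4 shows that such a group need not go with fast removal. Compound 1 and compound 4 each give only a limit, so the step between them cannot be read.

The compounds shown change the ring and the amine together, so a plain cyclohexyl group, or a dimethylamino group on an open chain, would be needed to tell which part goes with the lower number. From the compounds shown here alone, how far the true clearance of compound 4 lies beyond its limit also stays open.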